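This account rests on a few compounds, and the source may have more. Where it says the series, first, only, none or still open, it means among the compounds named here.

Working notes on the series, read in a physicochemical assay for solubility, read by spectrophotometry, measured as kinetic solubility, at pH 8, tested at 500 uM; a higher number here means a more soluble compound, a lower number a less soluble compound. Compound 1 (`CN1CCC(CNS(=O)(=O)c2ccccc2Nc2cc(-c3ccc4ccn(C)c4c3)c3nccnc3c2)C1`) gives 35 ug/mL and compound 2 (`CN(C)S(=O)(=O)c1ccccc1Nc1cc(-c2ccc3ccn(C)c3c2)c2nccnc2c1`) gives 2 ug/mL. Compound 3 (`CN1CCC(NS(=O)(=O)c2ccccc2Nc2cc(-c3ccc4ccn(C)c4c3)c3nccnc3c2)C1`) gives 26 ug/mL, within the scatter of compound 1 and well clear of compound 2. Compound 4 (`Cn1ccc2ccc(-c3cc(Nc4ccccc4S(=O)(=O)NCC4CCOCC4)cc4nccnc34)cc21`) has (oxan-4-yl)methyl in place of 1-methylpyrrolidin-3-yl on a sulfonamide nitrogen. Within the data shown here, no measured compound carries the oxan-4-yl group. Among the measured compounds shown here, the step of a 1.3-fold lower number from compound 1 to compound 3 (0.13 log units; within the scatter) lies within the scatter, whereas an 18-fold lower number from compound 1 to compound 2 (1.24 log units; beyond the scatter) and a 13-fold higher number from compound 2 to compound 3 (1.11 log units; beyond the scatter) are both large, and compound 2 is the only measured compound without the 1-methylpyrrolidine ring. A clear downward step is therefore expected in this assay, a 5.2-fold lower number from compound 3 to compound 4 (0.72 log units; beyond the scatter). The estimate for compound 4 is 5 ug/mL, with an expected range of 1.5 ug/mL to 15 ug/mL.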

Compound 4, solubility: 2 ug/mL
Compound 4: middle estimate off by 2.5-fold (0.40 log units), on the high side, within the range that was stated.
By their numbers in this assay, from the lowest: compounds 2 and 4 (each within the scatter of the next); then compounds 3 and 1 (each within the scatter of the next).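

In this assay, (oxan-4-yl)methyl on the sulfonamide nitrogen gives a 13-fold lower number from compound 3 to compound 4 (1.11 log units; beyond the scatter) and an 18-fold lower number from compound 1 to compound 4 (1.24 log units; beyond the scatter), so a saturated ring on this nitrogen does not by itself keep the number of compounds 1 and 3. With no change at the digits printed from compound 2 to compound 4 (within the scatter), the two compounds lacking the 1-methylpyrrolidine ring stand together among these four, whether or not they carry a ring. No measurement shown explains this result.

From the compounds shown here alone, whether the ring nitrogen or the ring size decides the result stays open. A (1-methylpiperidin-4-yl)methyl group on the same sulfonamide nitrogen would separate the two.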